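From 4-fluorophenyl to pyrazin-2-yl on the shared core

The compounds below may be only part of what the source reports. "The series", "measured", "known", "first", "only" and "open" are said of these compounds alone.

compound 1 `CC(C)CNC(=O)n1cc(-c2ccccc2)oc1=O`: 0.833 h
compound 2 `O=C(NCCCCc1ccccc1)n1cc(-c2ccc(F)cc2)oc1=O`: 1 h
compound 3 `O=C(NCCCCc1ccccc1)n1cc(-c2ccncc2)oc1=O`: > 1 h

In an ADME assay on microsomes from liver (Mus musculus) for metabolic stability, read by LC-MS, using NADPH, tested at 4.6 uM (on this read-out lower numbers stand for a shorter-lived compound and higher numbers for a longer-lived compound), compound 2, at 1 h, lies within the scatter of compound 1, at 0.833 h. The entry for compound 3, > 1 h, is a limit and not a number.

Compound 4 `O=C(NCCCCc1ccccc1)n1cc(-c2cnccn2)oc1=O` has not yet been measured. It carries pyrazin-2-yl in place of 4-fluorophenyl on an aromatic carbon.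

Among the measured compounds shown here, one measured step bears on this change, with pyridin-4-yl in place of 4-fluorophenyl at the same place: a number no lower from compound 2 to compound 3 (the limit leaves the size open). On these data alone, that step shows no fall, but its size stays open, as the limit of > 1 h in this assay, at which 1 of the 3 values shown sits, records. In this assay no change beyond the scatter is therefore expected, with any movement more likely upward than downward. The expected step is a 1.2-fold higher number from compound 2 to compound 4 (0.08 log units; within the scatter). For compound 4 the estimated half-life is 1.2 h, with an expected range of 0.6 h to 2.4 h.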

Compound 4, half-life: 1 h
For compound 4 the middle estimate is 1.2-fold (0.08 log units) above the measured one, and the stated range covers the measured number.
By their numbers in this assay, from the lowest: compounds 1, 2 and 4 (each within the scatter of the next).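

In this assay, the step of pyrazin-2-yl in place of 4-fluorophenyl on an aromatic carbon, next to the ring oxygen, reads: no change at the digits printed from compound 2 to compound 4 (within the scatter). Among the compounds shown here, this gives the first readable step at this place: a ring with 2 hetero atoms and 2 hydrogen-bond acceptors replaces a ring of carbon only with no visible effect on half-life, so this position tolerates the change in this read-out. For pyrazin-2-yl in place of pyridin-4-yl on an aromatic carbon, the data give a number no higher from compound 3 to compound 4 (the limit leaves the size open). The steps involving compound 3 cannot be read, so pyrazin-2-yl and pyridin-4-yl cannot be ranked, since the entry for compound 3 is a limit: the limit of > 1 h in this assay, at which 1 of the 4 values shown sits.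

The compounds shown leave open whether a group of another kind at this carbon, such as a carboxylic acid or an aminomethyl group, would move the half-life beyond the scatter. They also leave open whether a longer chain on the amide nitrogen would alter the outcome of this change.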